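A few compounds are considered here, and "the series" means these few. Any claim that something is new, unique, unknown or untested is made for them only; others in the source may bear on it.

Of the compounds shown here, three of one shared core have so far been measured in a functional assay on SNB-75 cells (Homo sapiens) for inhibition, read by sulforhodamine B assay, with a stated time of 48 h; on this read-out lower numbers stand for stronger inhibition of growth and higher numbers for weaker inhibition of growth. Compound 1 `COc1ccc(CNc2nc3cc(N)cc(N)c3nc2-c2ccccc2)cc1OC` gives 16200 nM. Compound 2 `COc1cc(CNc2nc3cc(N)cc(N)c3nc2-c2ccccc2)cc(OC)c1OC` gives 813 nM, and compound 3 `Nc1cc(N)c2nc(-c3ccccc3)c(NCc3ccc(F)cc3)nc2c1` gives 2140 nM. On these numbers compound 3 stands second highest of the three: its number sits between that of compound 2, which is lower, and that of compound 1, which is higher.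

Two single-point steps are known. Adding a methoxy to an aromatic carbon produced a 20-fold lower number from compound 1 to compound 2 (1.30 log units; beyond the scatter). Exchanging the aryl group on the saturated chain carbon bound to the ring nitrogen produced a 7.6-fold lower number from compound 1 to compound 3 (0.88 log units; beyond the scatter).

Compound 4 `Nc1cc(N)c2nc(-c3ccccc3)c(Oc3ccc(F)cc3)nc2c1` is not yet measured. It differs from compound 3 by 4-fluorophenoxy in place of (4-fluorobenzyl)amino on an aromatic carbon. Within the data shown here, no measured step alters the linking group itself; the step from compound 1 to compound 3 shows only that changes within this side chain shift the number by a modest amount. The change here removes the hydrogen-bond donor and shortens the link by one atom, so an expected step of modest size, toward a higher number, seems the likeliest outcome, with no step beyond the scatter also possible. For compound 4 the expected step is a 1.6-fold higher number from compound 3 to compound 4 (0.21 log units; within the scatter). Compound 4 is therefore estimated at 3500 nM, in a range from 900 nM to 14000 nM.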

Compound 4, concentration for 50% growth inhibition: 23400 nM
For compound 4 the middle estimate is 6.7-fold (0.83 log units) below the measured one; the measured number lies above the stated range.
By their numbers in this assay, from the lowest: compound 2; then compound 3; then compounds 1 and 4 (each within the scatter of the next).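

In this assay, the link that joins the 4-fluorophenyl ring to the shared core matters a great deal: with that ring unchanged, 4-fluorophenoxy in place of (4-fluorobenzyl)amino gives an 11-fold higher number from compound 3 to compound 4 (1.04 log units; beyond the scatter). Among these compounds, the earlier steps changed only the aryl part of the side chain or its methoxy groups, so this is the first sign that growth inhibition at this position is sensitive to the link itself, and here the swap weakens it. Two things change at once, since the entering group has 0 hydrogen-bond donors where the leaving group has 1, and an oxygen replaces the nitrogen and its chain carbon, but no available evidence says why the number rises.

The compounds shown cannot separate those two changes: a 4-fluorobenzyloxy group would replace the nitrogen while keeping the chain carbon, whereas a 4-fluoroanilino group would keep the nitrogen and drop that carbon. From the compounds shown here alone, it also remains open whether the same link swap would have a similar effect with another aryl group, such as the 3,4,5-trimethoxyphenyl of compound 2.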